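Changing the aryl group on a shared core

The source may report more compounds than this note shows. Statements on the series, on what has been measured and on what is new or still open speak of the compounds shown alone.

Compound 1 `FC(F)(F)c1nc2c(Br)cccc2c(Cl)c1Br`: > 300000 nM
Compound 2 `COc1ccc(-c2cccc3c(Cl)c(Br)c(C(F)(F)F)nc23)cc1`: > 300000 nM

In an assay for inhibition of ectonucleoside triphosphate diphosphohydrolase 3 (Homo sapiens), read by malachite green, with a stated time of 10 min (a lower number here means a stronger inhibitor, a higher number a weaker inhibitor), compound 1 gives only a limit, > 300000 nM. Compound 2 likewise gives only a limit, > 300000 nM. Both sit at the limit of > 300000 nM in this assay, at which 2 of the 2 values shown sit, so the step that the two limits leave unreadable from compound 1 to compound 2 cannot be read. Compound 3 `N#Cc1cccc(-c2cccc3c(Cl)c(Br)c(C(F)(F)F)nc23)c1` differs from compound 2 by 3-cyanophenyl in place of 4-methoxyphenyl on an aromatic carbon. Within the data shown here, no measured step bears readably on this change, and compound 2 itself shows no number, only a limit. For compound 3 the estimate is 300000 nM, in the range 100000 nM to 1000000 nM, most likely again a limit. This estimate means an expected step of a number no higher from compound 2 to compound 3 (the limit leaves the size open), that is, none beyond the scatter.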

Compound 3, half-maximal inhibitory concentration: > 300000 nM
Compound 3: no number, only a limit; the forecaster's own chance of this, stated with the estimate: 85%; the middle value sits exactly at the limit.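

No new step can be read among compound 1, compound 2 and compound 3 in this assay, as each gives only a limit: the limit of > 300000 nM in this assay, at which 3 of the 3 values shown sit.

The compounds shown leave open which change on the shared core, if any, would give a readable number in this assay.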